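Cyclohexyloxy aryl glycosides: a stereocentre inversion on the core

The source may hold more compounds than are shown below. What is called first, only, known or untested is meant among the compounds shown, and "the series" means these compounds.

For the measured compounds named here, compound 1 `CO[C@H]1O[C@H](COc2ccc(OC3CCCCC3)cc2)[C@@H](O)[C@H](O)[C@H]1Oc1ccc(OC2CCCCC2)cc1` is the only member of the series with a number in hand. In a functional assay on MDA-MB-231 cells (Homo sapiens) for cytotoxicity, read by MTT assay, with a stated time of 48 h (on this read-out higher numbers stand for an effect only at larger amounts of compound and lower numbers for an effect already at smaller amounts), compound 1 gives 20000 nM. Going by the values given here, compound 2 `CO[C@@H]1O[C@H](COc2ccc3c(c2)CCCC3)[C@@H](O)[C@H](O)[C@H]1Oc1ccc(OC2CCCCC2)cc1` has no result in this assay, where compound 2 stands at "not determined" (no result reported), so no step between measured compounds exists and no sense of how the series moves can be drawn from it.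

Compound 3 `CO[C@@H]1O[C@H](COc2ccc(OC3CCCCC3)cc2)[C@@H](O)[C@H](O)[C@H]1Oc1ccc(OC2CCCCC2)cc1` is the next entry for this assay. Relative to compound 1 the difference is the two compounds have the same atoms and bonds and differ only in configuration as drawn: 1 of 5 stereo elements differ; a stereocentre at a saturated ring carbon is drawn S in compound 1 and R in compound 3. Among the compounds with values here, with nothing leaving or entering, and with no measured step to lean on, the expectation is that the step of no change at the digits printed from compound 1 to compound 3 (within the scatter) stays within the usual scatter, with no direction favoured. Compound 3 is therefore estimated at 20000 nM in this assay, with a range from 7000 nM to 55000 nM, the width reflecting that only compound 1 anchors the estimate.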

Compound 3, half-maximal effective concentration: 26000 nM
Beside the measured number, compound 3's estimate is 1.3-fold (0.11 log units) below it, within the range that was stated.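

Inverting the stereocentre at a saturated ring carbon, drawn S on one side of the pair and R on the other, gives a 1.3-fold higher number from compound 1 to compound 3 (0.11 log units; within the scatter) in this assay. For the compounds shown here, this is the first readable step, and it shows that, for this pair, the configuration at this one carbon leaves the read-out within the scatter. The comparison isolates a single change, with nothing leaving or entering: the fact that compounds 1 and 3 differ only in the configuration as drawn.

Going by these compounds alone, whether the other four stereo elements behave the same way remains open, and compound 2 offers no step that can be read. Also open, going by these compounds, is how the read-out responds when a cyclohexyloxy group gives way to an amine or a carboxylic acid on the shared core, in either configuration at this carbon.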